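Lengthening the side chain of compound 2

A few compounds are considered here, and "the series" means these few. Any claim that something is new, unique, unknown or untested is made for them only; others in the source may bear on it.

In an ADME assay on HEK293 cells (Homo sapiens) for cytotoxicity, read by MTT assay, with a stated time of 48 h (on this read-out lower numbers stand for stronger inhibition and higher numbers for weaker inhibition), compound 1 `CN(C)CCn1c(N)c(-c2nc3ccccc3[nH]2)c2nc(C#N)c(C#N)nc21` gives 9730 nM. Compound 2 `CN(C)CCn1c(N)c(-c2nc3ccccc3n2C)c2nc(C#N)c(C#N)nc21` is reported as > 50000 nM, which is a limit of the assay and not a number. Compound 2 thus stands at the limit of > 50000 nM in this assay, at which 1 of the 2 values shown sits, so it has no exact value to start from. It carries methyl in place of hydrogen on an aromatic nitrogen, and the result is an at least 5.1-fold higher number from compound 1 to compound 2 (0.71 log units; beyond the scatter), a step beyond the scatter. Compound 3 `CCN(CC)CCCCn1c(N)c(-c2nc3ccccc3n2C)c2nc(C#N)c(C#N)nc21` keeps that methyl and alters the side chain: 2-(diethylamino)ethyl in place of dimethylamino on a saturated chain carbon, two bonds along the chain from an aromatic nitrogen. Within the data shown here, the one measured step lies at a different place, so it bears on this change only indirectly, by showing that a single edit to the shared core can move the number clearly. With compound 1 at 9730 nM as the only exact reference, a modest fall in the number is expected. A result at the limit nevertheless remains quite possible. The expected size is an at least 1.6-fold lower number from compound 2 to compound 3 (0.22 log units; that floor lies within the scatter). For compound 3 the estimate is 30000 nM, with an expected range of 9000 nM to 50000 nM.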

Compound 3, half-maximal inhibitory concentration: 3160 nM
The estimate for compound 3 lay 9.5-fold (0.98 log units) above the measured number, outside the stated range (below it).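

Among these compounds, the side chain, which compound 1 and compound 2 share, is altered here for the first time, and the number proves sensitive to it. In this assay, putting 2-(diethylamino)ethyl in place of dimethylamino on a saturated chain carbon, two bonds along the chain from an aromatic nitrogen, gives an at least 15-fold lower number from compound 2 to compound 3 (1.19 log units; beyond the scatter), so the methyl on the aromatic nitrogen does not by itself keep the number at the top of the range. The true size of this step stays unknown, and its printed size is only a floor, because the value for compound 2 is a limit and not a number: the limit of > 50000 nM in this assay, at which 1 of the 3 values shown sits.

This single change both lengthens the chain, from 2-(dimethylamino)ethyl to 4-(diethylamino)butyl, and replaces the methyl groups on the amine nitrogen with ethyl groups, so the compounds shown cannot say which of the two accounts for the step. A 4-(dimethylamino)butyl chain would separate these two edits, and a 2-(diethylamino)ethyl chain in its place on the aromatic nitrogen would test the same question from the other side.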